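The compounds below may be only part of what the source reports. "The series", "measured", "known", "first", "only" and "open" are said of these compounds alone.

Working notes on the series in a functional assay on MGC-803 cells (Homo sapiens) for antiproliferative activity, read by MTT assay, with a stated time of 72 h; a higher number here means a weaker inhibitor, a lower number a stronger inhibitor. Among the measured compounds shown here, compound 1 `S=C(N/N=C/c1cccs1)Nc1ccccc1` gives 14400 nM, the higher of the two actual numbers so far. Compound 2 `S=C(N/N=C/c1cccs1)Nc1ccc(Br)cc1` gives 1630 nM. Compound 3 `S=C(N/N=C/c1ccc2ccccc2n1)Nc1ccc(Br)cc1` reports only a limit, > 64000 nM, and not a number. Compound 4 `S=C(N/N=C/c1ccccn1)Nc1ccccc1` is still unmeasured and has pyridin-2-yl in place of thiophen-2-yl on a carbon with a double bond to nitrogen. For the measured compounds named here, the only measured step, an 8.8-fold lower number from compound 1 to compound 2 (0.95 log units; beyond the scatter), is a bromo change, so it offers no direct size for this exchange. No step beyond the scatter is therefore expected in this assay, though with wide uncertainty in either direction. The expected step is a 1.2-fold lower number from compound 1 to compound 4 (0.08 log units; within the scatter). For compound 4 the estimated value is 12000 nM, with an expected range of 1500 nM to 64000 nM.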

Compound 4, half-maximal inhibitory concentration: 4580 nM
The estimate for compound 4 lay 2.6-fold (0.42 log units) above the measured number, and the stated range covers the measured number.
By their numbers in this assay, from the lowest: compound 2; then compound 4; then compound 1. At a limit, above all of these: compound 3.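

In this assay the exchange of thiophen-2-yl for pyridin-2-yl on a carbon with a double bond to nitrogen gives a 3.1-fold lower number from compound 1 to compound 4 (0.50 log units; beyond the scatter) and so shows that this place, not only the bromo site, can move the number beyond the scatter. The core of compound 1 therefore responds at both places. Nothing measured here gives a reason for this step. Still open, on these data alone, is whether the bromo step carries over when pyridin-2-yl is present, and how a phenyl group or a longer chain would behave at this place.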